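The source may hold more compounds than are shown below. What is called first, only, known or untested is meant among the compounds shown, and "the series" means these compounds.

Of the compounds shown here, three sharing a common core have been measured in an in vitro functional assay on cells for agonist activity at Bombesin receptor subtype-3 (Homo sapiens), read by luminescence and calcium flux; a lower number here means that less compound is needed, a higher number that more compound is needed for the effect. Compound 1 `O=C(O)c1ccccc1-c1ccc(CCc2ncc(CC3CCOCC3)[nH]2)cc1` gives 338 nM, compound 2 `O=C(O)c1ccccc1-c1ccc(CCc2ncc(CC3CCCC3)[nH]2)cc1` gives 133 nM, and compound 3 `O=C(O)c1ccccc1-c1ccc(CCc2ncc(Cc3ccc(Cl)cc3)[nH]2)cc1` gives 2290 nM. Compound 3 therefore stands with the highest number of the three: a 6.8-fold higher number from compound 1 to compound 3 (0.83 log units; beyond the scatter), and a 17-fold higher number from compound 2 to compound 3 (1.24 log units; beyond the scatter), while the remaining step, a 2.5-fold lower number from compound 1 to compound 2 (0.41 log units; beyond the scatter), separates the two saturated rings from each other.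

Compound 4 `O=C(O)c1ccccc1-c1ccc(CCc2ncc(Cc3ccc(F)cc3)[nH]2)cc1` differs from compound 3 in one place only: fluoro in place of chloro on an aromatic carbon. None of the three measured steps bears directly on this change; each of them exchanges the whole group on the saturated chain carbon, whereas here the 4-chlorobenzyl group keeps its shape and only chloro gives way to fluoro. Among the compounds with values here, the measured compounds thus offer no precedent for such an exchange, and the expected step in this assay from compound 3 to compound 4 is none beyond the scatter, estimated as a 1.1-fold higher number from compound 3 to compound 4 (0.04 log units; within the scatter). On that basis compound 4 is expected to give about 2500 nM in this assay, with a range from 1000 nM to 6500 nM, and the measurement will show whether it stays near compound 3.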

Compound 4, half-maximal effective concentration: 1600 nM
The estimate for compound 4 lay 1.6-fold (0.19 log units) above the measured number, and the stated range covers the measured number.
By their numbers in this assay, from the lowest: compound 2; then compound 1; then compounds 4 and 3 (each within the scatter of the next).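

In this assay, within the data shown here, the exchange of chloro for fluoro, on an aromatic carbon para to a large group, gives a 1.4-fold lower number from compound 3 to compound 4 (0.16 log units; within the scatter) and so leaves the number within the scatter, a kind of change that the earlier steps, each replacing the whole group on the saturated chain carbon, did not test. The disadvantage of the halogenated aromatic groups against the saturated rings is not confined to chloro, as 4-fluorophenyl in place of cyclopentyl gives a 12-fold higher number from compound 2 to compound 4 (1.08 log units; beyond the scatter) and 4-fluorophenyl in place of oxan-4-yl gives a 4.7-fold higher number from compound 1 to compound 4 (0.68 log units; beyond the scatter), both beyond the scatter. No measurement at hand offers an explanation for these results.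

Going by these compounds, it remains open whether this place on the aromatic ring responds to anything other than a halogen, such as a nitrile, a methoxy group or an amine in place of the fluoro. On these data alone, it is equally open whether a longer chain in place of the saturated chain carbon would change the standing of 4-fluorobenzyl against the cyclopentyl and oxan-4-yl groups.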